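Amide variation on the shared core: aryl versus phenylethenyl

This account rests on a few compounds, and the source may have more. Where it says the series, first, only, none or still open, it means among the compounds named here.

Measured compounds:
- compound 1 `Nc1ccc(C(=O)Nc2nnc(-c3ccc4c(c3)OCCO4)s2)cc1`: in a functional assay on BGC-823 cells (Homo sapiens) for antiproliferative activity, read by MTT assay, with a stated time of 48 h (on this read-out lower numbers stand for an effect already at smaller amounts and higher numbers for an effect only at larger amounts of compound), compound 1 gives > 100 ug/mL, which is a limit of the assay.
- compound 2 `O=C(Nc1nnc(-c2ccc3c(c2)OCCO3)s1)c1ccc(Cl)nc1`: compound 2 gives > 100 ug/mL, also a limit.
- compound 3 `O=C(/C=C/c1ccccc1)Nc1nnc(-c2ccc3c(c2)OCCO3)s1`: compound 3 gives 45.4 ug/mL.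

Among the measured compounds shown here, compound 3 is the only member with a read number; the other two values sit at the limit of > 100 ug/mL in this assay, at which 2 of the 3 values shown sit. Both aryl amides therefore remain unread, and the two steps toward the phenylethenyl amide, an at least 2.2-fold lower number from compound 1 to compound 3 (0.34 log units; beyond the scatter) and an at least 2.2-fold lower number from compound 2 to compound 3 (0.34 log units; beyond the scatter), are the only readable movements in the set. The step between the two aryl amides, a step that the two limits leave unreadable from compound 1 to compound 2, tells nothing.

Compound 4 `O=C(Nc1nnc(-c2ccc3c(c2)OCCO3)s1)c1ccccn1` is not yet measured. Its change from compound 3 is pyridin-2-yl in place of 2-phenylethenyl on a carbonyl carbon. This returns the amide to a six-membered aromatic ring, the kind of group that in compound 1 and compound 2 went with the limit. Both readable steps ran in the direction of phenylethenyl and were at least modest; the change here runs the other way. In this assay compound 4 is expected to show a higher number, probably again at the limit, so the estimated step of a 2.6-fold higher number from compound 3 to compound 4 (0.42 log units; beyond the scatter) is expected to reverse the earlier gains. The estimate for compound 4 is 120 ug/mL, with a range from 45 ug/mL to 400 ug/mL.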

Compound 4, half-maximal effective concentration: 35.8 ug/mL
Compound 4: the middle estimate sits 3.4-fold (0.53 log units) above what was measured; the measured number lies below the stated range.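

In this assay, a six-membered aromatic ring on the carbonyl carbon no longer goes with the limit alone, as the set now holds an at least 2.7-fold lower number from compound 1 to compound 4 (0.44 log units; beyond the scatter) and an at least 2.7-fold lower number from compound 2 to compound 4 (0.44 log units; beyond the scatter). A pyridine ring as such does not settle the outcome, as compound 2 also carries one, in the form of 6-chloropyridin-3-yl, and its value is a limit. The double bond outside aromatic rings in 2-phenylethenyl is also not needed for a read number at this place, and the two read amides cannot be told apart, with a 1.3-fold lower number from compound 3 to compound 4 (0.10 log units; within the scatter).

Whether the ring nitrogen of pyridin-2-yl, the chlorine of compound 2 or the amino group of compound 1 accounts for the separation among the aromatic amides stays open, and an unsubstituted phenyl, a pyridin-3-yl or a saturated chain such as cyclohexyl on the carbonyl carbon would bear on that question. The true size of the steps from the two aromatic amides that stay unread also remains open, as these are bounded on one side only: the limit of > 100 ug/mL in this assay, at which 2 of the 4 values shown sit.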